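The source may report more compounds than this note shows. Statements on the series, on what has been measured and on what is new or still open speak of the compounds shown alone.

Three compounds share one core and differ only in the group carried on an amide-type nitrogen. Compound 1 `C=CCN(Cc1cccs1)C(=O)COc1ccc(C)cc1` gives 20 nM in an assay on HEK293 cells for agonist activity at transient receptor potential cation channel subfamily M member 8 (Homo sapiens), read by fluorescence and calcium flux, with a stated time of 15 min (on this read-out lower numbers stand for an effect already at smaller amounts and higher numbers for an effect only at larger amounts of compound), compound 2 `Cc1ccc(OCC(=O)N(Cc2cccs2)c2ccccc2)cc1` gives 23 nM, and compound 3 `Cc1ccc(OCC(=O)N(Cc2cccs2)c2ccccn2)cc1` gives 200 nM, the highest of the three numbers. Compound 4 `CON(Cc1cccs1)C(=O)COc1ccc(C)cc1` differs from compound 3 by methoxy in place of pyridin-2-yl on an amide-type nitrogen. The steps of a 10-fold higher number from compound 1 to compound 3 (1.00 log units; beyond the scatter) and an 8.7-fold higher number from compound 2 to compound 3 (0.94 log units; beyond the scatter) show that pyridin-2-yl on an amide-type nitrogen goes with a clearly higher number than allyl or phenyl. Taking pyridin-2-yl away may therefore bring the number down again, but no measured compound carries methoxy there, so the size of that return is uncertain. Compound 4 is expected to give about 60 nM, with a range from 15 nM to 300 nM, an expected step of a 3.3-fold lower number from compound 3 to compound 4 (0.52 log units; beyond the scatter).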

Compound 4, half-maximal effective concentration: 10 nM
Compound 4: middle estimate off by 6.0-fold (0.78 log units), on the high side, and the stated range ends above it.
By their numbers in this assay, from the lowest: compounds 4, 1 and 2 (each within the scatter of the next, the first and the last beyond it); then compound 3.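

In this assay methoxy on the amide-type nitrogen fully removes the penalty seen with pyridin-2-yl, giving a 20-fold lower number from compound 3 to compound 4 (1.30 log units; beyond the scatter) in this change, and it also improves on phenyl, giving a 2.3-fold lower number from compound 2 to compound 4 (0.36 log units; beyond the scatter) in that comparison. Against allyl it shows a 2.0-fold lower number from compound 1 to compound 4 (0.30 log units; within the scatter) and no real difference, so an oxygen attached directly to this nitrogen is accepted. No measurement shown here explains these differences.

On these data alone, whether a hydroxy group, a longer ethoxy chain or a plain methyl would keep the number this low stays open.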